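Isopentyloxy in place of a piperidine on the benzylamide core

This account rests on a few compounds, and the source may have more. Where it says the series, first, only, none or still open, it means among the compounds named here.

Compounds measured so far:
Compound 1, `CC1CCN(c2cc(C(F)(F)F)ccc2CNC(=O)C(C)c2ccc(NS(C)(=O)=O)c(F)c2)CC1`, gives 0.9 nM in an assay on CHO cells for antagonist activity at transient receptor potential cation channel subfamily V member 1 (Homo sapiens), read by FLIPR; on this read-out higher numbers stand for weaker inhibition and lower numbers for stronger inhibition.
Compound 2, `CC(C(=O)NCc1ccc(C(F)(F)F)cc1N1CCC(c2ccc(F)cc2)CC1)c1ccc(NS(C)(=O)=O)c(F)c1`, gives 0.9 nM in this assay.
Compound 3, `CC(C(=O)NCc1ccc(C(F)(F)F)cc1N1CCC(Cc2ccc(F)cc2)CC1)c1ccc(NS(C)(=O)=O)c(F)c1`, gives 0.4 nM in this assay.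

Compound 1 stands level with compound 2, and together they carry the highest numbers of the three, as no change at the digits printed from compound 1 to compound 2 (within the scatter) shows. Compound 3 sits apart from both: a 2.3-fold lower number from compound 1 to compound 3 (0.35 log units; beyond the scatter) and a 2.3-fold lower number from compound 2 to compound 3 (0.35 log units; beyond the scatter) are modest steps, yet beyond the scatter. All three measured steps move groups around the saturated ring attached to the core.

Compound 4, `CC(C)CCOc1cc(C(F)(F)F)ccc1CNC(=O)C(C)c1ccc(NS(C)(=O)=O)c(F)c1`, has not yet been measured. It differs from compound 1 in one place: isopentyloxy in place of 4-methylpiperidin-1-yl on an aromatic carbon. Among the compounds with values here, none of the measured steps alters this part of the molecule in the same way; they only show that changes on the saturated ring produce small or no shifts in this assay. Swapping the whole ring for a chain with an oxygen linker is a larger departure, so compound 4 is expected to show some loss of potency, with a 2.8-fold higher number from compound 1 to compound 4 (0.44 log units; beyond the scatter) as the estimated step. Compound 4 is therefore estimated at 2.5 nM, in a range from 0.8 nM to 8 nM.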

Compound 4, inhibition constant: 0.5 nM
For compound 4 the middle estimate is 5.0-fold (0.70 log units) above the measured one, and the stated range ends above it.
By their numbers in this assay, from the lowest: compounds 3, 4, 1 and 2 (each within the scatter of the next, the first and the last beyond it).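

In this assay, isopentyloxy in place of 4-methylpiperidin-1-yl on this aromatic carbon, meta to a trifluoromethyl group, gives a 1.8-fold lower number from compound 1 to compound 4 (0.26 log units; within the scatter), so the read-out does not separate the two compounds. The earlier compounds shown here changed only what the saturated ring carries, and all of them kept that ring on the core; compound 4 shows that a value at this level does not depend on the ring, since an open chain joined through oxygen serves as well. Nothing available here accounts for why these two quite different groups read alike.

The compounds shown leave open whether the ether oxygen or the branched chain matters more at this position, which a nitrogen-linked isopentylamino group or a shorter ethoxy group on the same core would begin to separate. They also leave open whether the chain tolerates further substitution, for instance a 4-fluorophenyl group at its far end, or a cyclohexyloxy group that would bring a saturated ring back behind the oxygen.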